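Ring contraction on the aromatic nitrogen: piperidine to pyrrolidine

The source may hold more compounds than are shown below. What is called first, only, known or untested is meant among the compounds shown, and "the series" means these compounds.

Compound 1 `CN1CCN(c2ccc(Nc3ncc4nc(Nc5ccc(F)cc5)n([C@H]5CCCN(S(=O)(=O)C6CC6)C5)c4n3)cc2)CC1`: 1150 nM
Compound 2 `CN1CCN(c2ccc(Nc3ncc4nc(Nc5ccccc5)n([C@H]5CCNC5)c4n3)cc2)CC1`: "not determined" (no result reported)

In a functional assay on NCI-H1975 cells (Homo sapiens) for antiproliferative activity, read by MTT assay, with a stated time of 72 h (on this read-out higher numbers stand for weaker inhibition and lower numbers for stronger inhibition), compound 1 gives 1150 nM. Among the compounds with values here, this is the only number available; compound 2 gives "not determined" (no result reported), so compound 1 cannot be placed against any other measured compound, and no measured step is known. Compound 3 `CN1CCN(c2ccc(Nc3ncc4nc(Nc5ccc(F)cc5)n([C@@H]5CCN(S(=O)(=O)C6CC6)C5)c4n3)cc2)CC1` differs from compound 1 in one place: 1-(cyclopropylsulfonyl)pyrrolidin-3-yl in place of 1-(cyclopropylsulfonyl)piperidin-3-yl on an aromatic nitrogen. The substituent keeps its cyclopropylsulfonyl part and loses one ring atom, the six-membered ring becoming a five-membered one. Within the data shown here, with a single measured value and no measured step to lean on, a step from compound 1 to compound 3 of no more than the usual scatter is expected, in no particular direction. Compound 3 is therefore estimated at 1200 nM, within a range of 400 nM to 3600 nM, an expected step of a 1.0-fold higher number from compound 1 to compound 3 (0.02 log units; within the scatter).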

Compound 3, half-maximal inhibitory concentration: > 10000 nM
Compound 3: no number, only a limit; the forecaster's own chance of this, stated with the estimate: 5%; middle value at least 8.3-fold (0.92 log units) away from the limit.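

In this assay, this place on the aromatic nitrogen proves sensitive to ring size, with an at least 8.6-fold higher number from compound 1 to compound 3 (0.93 log units; beyond the scatter). Compound 3 reads > 10000 nM, which is a limit of the assay and not a number. Losing one ring atom while the cyclopropylsulfonyl part stays is thus enough to carry the result beyond the scatter, though the full size of the step cannot be read: the limit of > 10000 nM in this assay, at which 1 of the 3 values shown sits.

On these data alone, it remains open how an azepane ring would behave at this place, or whether a pyrrolidine carrying a methylsulfonyl or acetyl group on its ring nitrogen would show the same loss. A single pair also cannot say whether the step would look the same if a pyridinylamino group stood in place of the (4-fluorophenyl)amino group.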